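Aryl Swap on a Shared Core, Growth Inhibition Expected Unchanged

The source may hold more compounds than are shown below. What is called first, only, known or untested is meant among the compounds shown, and "the series" means these compounds.

Measured compounds:
compound 1, `COc1cc(/C=C/C(=O)c2cccc(-n3cc(-c4ccc(Cl)cc4)[nH]c3=O)c2)cc(OC)c1OC`, 1720 nM
compound 2, `O=C(/C=C/c1cccc(O)c1)c1cccc(-n2cc(-c3ccccc3)[nH]c2=O)c1`, 1850 nM
compound 3, `COc1ccc(-c2cn(-c3cccc(C(=O)/C=C/c4ccc(O)c(OC)c4)c3)c(=O)[nH]2)cc1`, 2440 nM

In a functional assay on LOX IMVI cells (Homo sapiens) for inhibition (a higher number here means a weaker inhibitor of growth, a lower number a stronger inhibitor of growth), compound 1 gives 1720 nM. Compound 2 gives 1850 nM and compound 3 gives 2440 nM in this assay. Compound 1 sits at the low end of this small spread, but neither neighbour is separated from it beyond the scatter: compound 2 is the nearer of the two and compound 3 the further, and both lie within the usual variation of repeated measurements. The three values therefore say little more than that all three compounds land in the same region.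

Compound 4, `COc1cc(/C=C/C(=O)c2cccc(-n3cc(-c4cc(OC)c(OC)c(OC)c4)[nH]c3=O)c2)cc(OC)c1OC`, has not yet been measured in this assay. It differs from compound 1 in one place: 3,4,5-trimethoxyphenyl in place of 4-chlorophenyl on an aromatic carbon. Among the measured compounds shown here, no pair of measured compounds shares this exact change, so nothing in the present data sets its direction. Given that the three measured compounds, which vary in the aryl groups they carry, all fall within scatter of one another, the step from compound 1 to compound 4 is expected to be a 1.2-fold higher number from compound 1 to compound 4 (0.07 log units; within the scatter), that is, no change beyond the scatter. Compound 4 is accordingly estimated at 2000 nM, with a range from 900 nM to 4500 nM.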

Compound 4, concentration for 50% growth inhibition: 1230 nM
The estimate for compound 4 lay 1.6-fold (0.21 log units) above the measured number; the range from low to high includes it.
By their numbers in this assay, from the lowest: compounds 4, 1, 2 and 3 (each within the scatter of the next).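

Among the compounds shown here, the step from 4-chlorophenyl to 3,4,5-trimethoxyphenyl on this aromatic carbon gives the first comparison in this assay in which the two compounds differ in one place only, and it reads a 1.4-fold lower number from compound 1 to compound 4 (0.15 log units; within the scatter). For the compounds shown here, at this position, then, the aryl group can go from 7 to 12 heavy atoms, and from 0 to 3 hydrogen-bond acceptors, with no shift in growth inhibition beyond the scatter, something the earlier compounds, which differ from one another in more than one place, could not show. Nothing measured here accounts for why these two aryl groups read alike.

A single step at this position cannot show whether it tolerates other groups in general: an aryl ring carrying an amine or a carboxylic acid, or a plain alkyl chain in place of the aryl ring, might still move the number beyond the scatter. As far as these compounds go, compound 2 and compound 3 also differ from compound 1 in more than one place, so the part played by the aryl group on the other side of the carbonyl remains open.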